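This account rests on a few compounds, and the source may have more. Where it says the series, first, only, none or still open, it means among the compounds named here.

Measured compounds in an assay on membranes from HeLa cells for displacement of a labelled ligand from adenosine receptor A3 (Homo sapiens), read by scintillation counting, with a stated time of 180 min, tested at 1 uM; on this read-out higher numbers stand for more inhibition at the one concentration tested (going by the name of the read-out) and lower numbers for less inhibition:
- compound 1, `CC1=C(C(=O)OCc2ccccc2)C(c2ccco2)NC(=O)N1C`: 11%
- compound 2, `COC(=O)C1=C(C)N(C)C(=O)NC1c1ccoc1`: 7%
- compound 3, `CC1=C(C(=O)OC(C)(C)C)C(c2ccoc2)NC(=O)N1C`: 12%

All three numbers are small, and compound 3 has the highest of them, though its gap to compound 1 and to compound 2 lies within the scatter, so no ordering among the three can be claimed. Among the measured compounds shown here, the only single-point step in this set, a number 5 percentage points higher from compound 2 to compound 3 (within the scatter), comes from a change of the ester group and stays within the scatter as well.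

Compound 4, `CC1=C(C(=O)OCc2ccccc2)C(c2ccoc2)NC(=O)N1C`, is compound 3 with another ester group: benzyl in place of tert-butyl on an oxygen next to a carbonyl group. The step from compound 2 to compound 3 is the closest guide, since it also swaps one ester group for another, and it shows essentially no movement. Compound 1 carries the same benzyl ester as compound 4 but differs from it elsewhere in the core, and compound 1 gives 11%, again a low number. Taken together, no step beyond the scatter is expected in this assay for the change to compound 4; the expected step is a number 1 percentage points lower from compound 3 to compound 4 (within the scatter). Compound 4 is therefore estimated at 11%, with a range from 2% to 21%.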

Compound 4, a percentage reported as inhibition, at one concentration (the size of the read-out at that concentration, not a potency): 25%
Compound 4: middle estimate off by 14 percentage points, on the low side; the measured number lies above the stated range.
By their numbers in this assay, from the lowest: compounds 2, 1 and 3 (each within the scatter of the next); then compound 4.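

In this assay, the ester group can move the number after all: benzyl in place of tert-butyl on the oxygen gives a number 13 percentage points higher from compound 3 to compound 4 (beyond the scatter), and phenyl in place of hydrogen on the saturated chain carbon bound to that oxygen gives a number 18 percentage points higher from compound 2 to compound 4 (beyond the scatter), while the earlier change from methyl to tert-butyl gave only a number 5 percentage points higher from compound 2 to compound 3 (within the scatter). The benzyl ester is not enough by itself, as compound 1 carries it and gives 11%, and furan-3-yl in place of furan-2-yl on the saturated ring carbon gives a number 14 percentage points higher from compound 1 to compound 4 (beyond the scatter), so in these compounds the higher number appears only when benzyl and furan-3-yl occur together. Nothing available here explains either step.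

The compounds shown leave open whether the rise follows the aromatic ring of the benzyl group or simply its added carbons, a question that a cyclohexylmethyl ester or a phenylethyl ester could help settle. They also leave open how a methyl or tert-butyl ester behaves with furan-2-yl, and, since each number comes from a single concentration, what the potency of compound 4 is.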